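Swapping cyclohexyl for benzyl on the ring nitrogen

The source may hold more compounds than are shown below. What is called first, only, known or untested is meant among the compounds shown, and "the series" means these compounds.

Of the compounds shown here, three sharing one core have been tested in a functional assay on MDA-MB-231 cells (Homo sapiens) for inhibition, read by sulforhodamine B assay, with a stated time of 48 h, tested at 10 uM; on this read-out lower numbers stand for less inhibition and higher numbers for more inhibition at the one concentration tested (going by the name of the read-out). Compound 1 `c1ccc2c(-c3cn4ccnc4c(-c4ccc5ncn(C6CCCCC6)c5c4)n3)cccc2c1` gives 20.8%. Compound 2 `Fc1ccc(-c2cn3ccnc3c(-c3ccc4ncn(C5CCCCC5)c4c3)n2)cc1` gives 15.8%, and compound 3 `c1csc(-c2cn3ccnc3c(-c3ccc4ncn(C5CCCCC5)c4c3)n2)c1` gives 10.8%. Among the compounds with values here, of the three numbers, the one for compound 1 is the highest, but the step of a number 5 percentage points lower from compound 1 to compound 2 (within the scatter) and the step of a number 10 percentage points lower from compound 1 to compound 3 (within the scatter) both lie within the scatter, as does the step of a number 5 percentage points lower from compound 2 to compound 3 (within the scatter), so the three compounds cannot be told apart on these figures.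

Compound 4 `c1ccc(Cn2cnc3ccc(-c4nc(-c5cccc6ccccc56)cn5ccnc45)cc32)cc1` has not yet been measured. It differs from compound 1 in one place: benzyl in place of cyclohexyl on an aromatic nitrogen. All three measured steps concern the group on the aromatic carbon, where naphthalen-1-yl, 4-fluorophenyl and thiophen-2-yl were compared; none of them touches the group on the aromatic nitrogen. Within the data shown here, there is therefore no measured step that bears on this change, and the only guide is that the three exchanges made so far all stayed within the scatter in this assay.

On that basis, the expected step of a number 0.8 percentage points lower from compound 1 to compound 4 (within the scatter) is none beyond the scatter, and compound 4 is estimated at 20%, with a range from 5% to 40%.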

Compound 4, a percentage reported as inhibition, at one concentration (the size of the read-out at that concentration, not a potency): 28.7%
Beside the measured number, compound 4's estimate is 8.7 percentage points below it, and the stated range covers the measured number.
By their numbers in this assay, from the lowest: compounds 3, 2, 1 and 4 (each within the scatter of the next, the first and the last beyond it).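

Within the data shown here, this is the first exchange on the aromatic nitrogen rather than on the aromatic carbon, and in this assay benzyl in place of cyclohexyl gives a number 7.9 percentage points higher from compound 1 to compound 4 (within the scatter) and so stays inside the usual spread of repeated measurements. At this position, then, a six-membered non-aromatic ring of carbon only and a benzyl group carrying a six-membered aromatic ring cannot be told apart at the one concentration tested, with naphthalen-1-yl held on the aromatic carbon. No measurement at hand speaks to what lies behind this small step.

The compounds shown leave open whether a group of a different kind on the ring nitrogen, such as an amine, a carboxylic acid or a longer alkyl chain, would move the number beyond the scatter. They also leave open whether benzyl behaves the same way when the aromatic carbon carries 4-fluorophenyl or thiophen-2-yl instead of naphthalen-1-yl, and how any of these compounds would compare across a range of concentrations.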